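Methoxy for Bromophenyl on an Already Inactive Compound

A few compounds are considered here, and "the series" means these few. Any claim that something is new, unique, unknown or untested is made for them only; others in the source may bear on it.

Compound 1, `CC1(c2ccccc2)CC(=O)C(C2CC(c3ccc(-c4ccc(Br)cc4)cc3)Cc3ccccc32)=C(O)O1`, gives 1800 nM in a functional assay on SK-OV-3 cells (Homo sapiens) for inhibition, with a stated time of 72 h; on this read-out lower numbers stand for stronger inhibition and higher numbers for weaker inhibition.
Compound 2, `COc1ccc(C2Cc3ccccc3C(C3=C(O)OC(C)(c4ccccc4)CC3=O)C2)cc1`, reaches only the assay limit of > 10000 nM in this assay.
Compound 3, `CCC1(c2ccccc2)CC(=O)C(C2CC(c3ccc(-c4ccc(Br)cc4)cc3)Cc3ccccc32)=C(O)O1`, likewise reaches only the assay limit of > 10000 nM in this assay.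

Compound 3 thus stands at the top of the shown numbers, where a limit rather than a number is reported; this is also the position of the limit of > 10000 nM in this assay, at which 2 of the 3 values shown sit. The step of an at least 5.5-fold higher number from compound 1 to compound 3 (0.74 log units; beyond the scatter) shows what the added methyl on the saturated chain carbon cost against compound 1. Compound 4, `CCC1(c2ccccc2)CC(=O)C(C2CC(c3ccc(OC)cc3)Cc3ccccc32)=C(O)O1`, carries the change (methoxy in place of 4-bromophenyl on an aromatic carbon). The same exchange was measured once, as an at least 5.5-fold higher number from compound 1 to compound 2 (0.74 log units; beyond the scatter), and that step was at least modest and away from potency. Both changes that weakened compound 1 are combined in compound 4, so no return toward a measurable number is expected, and the step that the limit leaves unreadable from compound 3 to compound 4 is estimated to stay at or beyond the limit. Compound 4 is therefore expected to give about 30000 nM in this assay, within a range from 10000 nM to 100000 nM.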

Compound 4, half-maximal inhibitory concentration: > 10000 nM
Compound 4: only a limit was reported; the forecaster's own chance of this, stated with the estimate: 90%; the middle value does not contradict the limit.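

Compound 4 reaches only a limit, > 10000 nM, in this assay. Its steps from compound 2 and compound 3 cannot be read, since those compounds also sit at that limit: the limit of > 10000 nM in this assay, at which 3 of the 4 values shown sit.

From the compounds shown here alone, how compound 2, compound 3 and compound 4 rank among themselves remains open.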